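A Cyclobutyl Swapped for Isopropyl on the Seven-Membered Ring

The compounds below may be only part of what the source reports. "The series", "measured", "known", "first", "only" and "open" are said of these compounds alone.

Values in a physicochemical assay for lipophilicity, read by HPLC, using the shake flask method, measured as octanol-water partition (on this read-out higher numbers stand for higher lipophilicity and lower numbers for lower lipophilicity), for the compounds measured so far:
Compound 1 `O=C(C1CC12CCN(C1CCOCC1)CC2)N1CCN(C2CC2)CC1` gives "not determined" (no result reported)
Compound 2 `O=C(C1CC12CCN(Cc1ccccc1)CC2)N1CCN(C2CCCCC2)CC1` gives 2.81
Compound 3 `O=C(C1CC2(CCN(C3CCOCC3)CC2)C1)N1CCCN(C2CCC2)CC1` gives -0.89

For the measured compounds named here, only two of the three compounds carry a number, and compound 3 is the lower of them. Compound 3 reads -0.89 in this assay while compound 2 reads 2.81 in the same measurement, a gap well beyond the usual scatter. Compound 1 offers no number for comparison.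

The next compound to be measured is compound 4 `CC(C)N1CCCN(C(=O)C2CC3(CCN(C4CCOCC4)CC3)C2)CC1`, which shares the core of compound 3. It has isopropyl in place of cyclobutyl on an amine nitrogen in a ring. Going by the values given here, no measured pair in the set differs in one place only, so the data offer no direct precedent for this swap. The expectation therefore rests on the structural change alone and on compound 3 as the starting point, at -0.89 in this assay as its anchor. A small downward step is expected, one not likely to go beyond the scatter. The estimated change is a number 0.21 log units lower from compound 3 to compound 4 (within the scatter) in this assay as a central figure. Compound 4 is estimated at -1.1 in this assay with -1.5 to -0.7 as its expected range.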

Compound 4, distribution coefficient: -1.78
Compound 4: the middle estimate sits 0.68 log units above what was measured; measured number below the stated range.
By their numbers in this assay, from the lowest: compound 4; then compound 3; then compound 2.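

For the compounds shown here, replacing cyclobutyl with isopropyl gives the first comparison in the set between compounds that differ in one place, and in this assay the change is a number 0.89 log units lower from compound 3 to compound 4 (beyond the scatter). It shows that on this amine nitrogen of the seven-membered ring, three ring bonds from the ring nitrogen and three ring bonds from the ring atom that bears a large group, the read-out responds beyond the scatter when a group of 3 heavy atoms with no ring replaces a four-membered carbon ring of 4 heavy atoms, although the counted hydrogen-bond donors, acceptors and net charge stay the same. Nothing in the available data accounts for the size or direction of this step, which stands here as an observation only.

The compounds shown leave open how the read-out would respond to a tert-butyl group, an oxetanyl group or a longer chain such as n-butyl on the same nitrogen. Going by these compounds alone, they also leave open whether the swap from cyclobutyl to isopropyl would give a similar step on a different core, since this single pair is the only example of it.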